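This account rests on a few compounds, and the source may have more. Where it says the series, first, only, none or still open, it means among the compounds named here.

In an ADME assay on Akata cells (Homo sapiens) for cytotoxicity, with a stated time of 7 days (on this read-out higher numbers stand for lower toxicity in this test and lower numbers for higher toxicity in this test), three compounds built on one shared core have been measured. Compound 1 `Nc1nc(OCC(F)(F)F)c2ncn(/C=C3/CC3(CO)CO)c2n1` gives only a limit of the assay, > 20000 nM. Compound 2 `CCCSc1nc(N)nc2c1ncn2/C=C1/CC1(CO)CO` likewise gives a limit, > 20000 nM. Compound 3 `Nc1nc(NCc2ccccc2)c2ncn(/C=C3/CC3(CO)CO)c2n1` also stands at a limit, > 24000 nM. Two of these values sit at the limit of > 20000 nM in this assay, at which 2 of the 3 values shown sit, and one at the limit of > 24000 nM in this assay, at which 1 of the 3 values shown sits, so the steps a step that the two limits leave unreadable from compound 1 to compound 2, a step that the two limits leave unreadable from compound 1 to compound 3 and a step that the two limits leave unreadable from compound 2 to compound 3 cannot be read in size or direction. Compound 4 `CC(C)CNc1nc(N)nc2c1ncn2/C=C1/CC1(CO)CO` differs from compound 3 by isopropyl in place of phenyl on a saturated chain carbon bound to a nitrogen on an aromatic ring. With no readable step among the measured compounds, no step beyond the scatter is expected in this assay. Compound 4 is estimated at 30000 nM, within 15000 nM to 80000 nM. The expected step that the limit leaves unreadable from compound 3 to compound 4 is taken to stay within the scatter.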

Compound 4, half-maximal cytotoxic concentration: > 24000 nM
Compound 4 gave a limit, no number (the forecaster's own chance of this, stated with the estimate: 85%); the middle value does not contradict the limit.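

In this assay, for the compounds shown here, compound 4 gives only a limit, as do compound 1, compound 2 and compound 3, so no step to compound 4 can be read in size or direction. The compounds shown leave open what half-maximal cytotoxic concentration any of them actually has, and whether these group changes alter it.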